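Indane amine spacer variation on the tryptamine piperidine series

A few compounds are considered here, and "the series" means these few. Any claim that something is new, unique, unknown or untested is made for them only; others in the source may bear on it.

Among the compounds with values here, compound 2 `CC(C)=CCN(C)C1CCN(CCCc2c[nH]c3ccc(-n4cnnc4)cc23)CC1` gives 1.8 nM in an assay on CHO cells for agonist activity at 5-hydroxytryptamine receptor 1D (Homo sapiens), read by GTPgammaS binding (on this read-out higher numbers stand for an effect only at larger amounts of compound and lower numbers for an effect already at smaller amounts), and holds the lowest of the two numbers measured so far. Its nearest neighbour, compound 1 `O[C@@H]1Cc2ccccc2[C@H]1NC1CCN(CCCc2c[nH]c3ccc(-n4cnnc4)cc23)CC1`, gives 13 nM; the step of a 7.2-fold lower number from compound 1 to compound 2 (0.86 log units; beyond the scatter) separates the two, with the methyl(3-methylbut-2-en-1-yl)amino group of compound 2 replacing the (2-hydroxy-2,3-dihydro-1H-inden-1-yl)amino group of compound 1 on a saturated ring carbon.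

Compound 3 `c1ccc2c(c1)CCC2NCC1CCN(CCCc2c[nH]c3ccc(-n4cnnc4)cc23)CC1` is not yet measured. It differs from compound 2 by ((2,3-dihydro-1H-inden-1-yl)amino)methyl in place of methyl(3-methylbut-2-en-1-yl)amino on a saturated ring carbon. Within the data shown here, the only step that bears on it is the one from compound 1 to compound 2, which ran from an indane-bearing amine to the open-chain methyl(3-methylbut-2-en-1-yl)amino group and lowered the number beyond the scatter. Compound 3 carries the indane amine again, though without the hydroxyl and with a methylene inserted before the nitrogen, so a partial reversal of that step is expected: a modest rise in the number, a 3.3-fold higher number from compound 2 to compound 3 (0.52 log units; beyond the scatter), is estimated. For compound 3 a value of 6 nM is therefore expected, in a range from 2 nM to 20 nM.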

Compound 3, half-maximal effective concentration: 1.3 nM
The estimate for compound 3 lay 4.6-fold (0.66 log units) above the measured number; measured number below the stated range.
By their numbers in this assay, from the lowest: compounds 3 and 2 (each within the scatter of the next); then compound 1.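

In this assay the indane is tolerated at this position: the change gives a 1.4-fold lower number from compound 2 to compound 3 (0.14 log units; within the scatter) and so leaves the open-chain methyl(3-methylbut-2-en-1-yl)amino group and ((2,3-dihydro-1H-inden-1-yl)amino)methyl indistinguishable, even though the entering group brings one five-membered non-aromatic ring, one six-membered aromatic ring and a hydrogen-bond donor. The indane as such therefore cannot account for the higher number of compound 1, since an indane is also present in the change that gives a 10-fold lower number from compound 1 to compound 3 (1.00 log units; beyond the scatter) and this change removes the hydroxyl and adds a methylene before the nitrogen. No measurement on hand explains either step.

Still open, going by these compounds, is which of those two differences carries the step from the hydroxylated indane amine, a question that the hydroxyl-free (2,3-dihydro-1H-inden-1-yl)amino group attached directly to the saturated ring carbon would address. Also open, on these data alone, is how far this tolerance extends, for example to a benzylamino group or to a longer chain between the saturated ring and the amine nitrogen.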